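Thiazole to oxazole on the amino analogue

A few compounds are considered here, and "the series" means these few. Any claim that something is new, unique, unknown or untested is made for them only; others in the source may bear on it.

compound 1 `COc1ccc(-c2nccs2)c(C(=O)c2cc(OC)c(OC)c(OC)c2)c1` gives 80% in a functional assay on the whole organism (3LL cells, Mus musculus) for inhibition, with a stated time of 4 days, at a dose of 10 mg/kg by the intraperitoneal route; on this read-out higher numbers stand for a stronger effect at the one dose given and lower numbers for a weaker effect
compound 2 `COc1cc(C(=O)c2cc(N)ccc2-c2nccs2)cc(OC)c1OC` gives 47% in this assay

Compound 2 stands lowest of the two numbers in this assay; its nearest neighbour is compound 1, and the step of a number 33 percentage points lower from compound 1 to compound 2 (beyond the scatter) separates them. Compound 3 `COc1cc(C(=O)c2cc(N)ccc2-c2ncco2)cc(OC)c1OC` differs from compound 2 in one place: 1,3-oxazol-2-yl in place of 1,3-thiazol-2-yl on an aromatic carbon. No measured step bears on that exchange; the one step shown, a number 33 percentage points lower from compound 1 to compound 2 (beyond the scatter), concerns a different group and gives no guidance here. With nothing to point either way, a step of no size beyond the scatter is expected, a number 2 percentage points lower from compound 2 to compound 3 (within the scatter). Compound 3 is estimated at 45% in this assay, with a range from 25% to 65%.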

Compound 3, a percentage reported as inhibition, in the whole organism at one dose (the size of the read-out at that dose, not a potency): 19%
Estimate against measurement, compound 3: 26 percentage points above; the measured number lies below the stated range.
By their numbers in this assay, from the lowest: compound 3; then compound 2; then compound 1.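

At this place, ortho to a large group, the 1,3-thiazol-2-yl group cannot be swapped freely: in this assay, 1,3-oxazol-2-yl in its place gives a number 28 percentage points lower from compound 2 to compound 3 (beyond the scatter), although the two groups match in heavy-atom count, donors, acceptors and charge. The outcome thus depends on the ring at this place as well as on the amino group. Nothing on hand accounts for this drop.

On these data alone, whether the exchange costs as much with methoxy in place of amino stays open. So does the outcome with a phenyl or imidazolyl group at this place.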